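Taking the 2-aminoethyl chain off compound 3

The source may hold more compounds than are shown below. What is called first, only, known or untested is meant among the compounds shown, and "the series" means these compounds.

- compound 1 `CCn1c(C(=O)N[C@H](C)C(=O)OC)ccc1C(CC)(CC)c1ccc(OCS(=O)(=O)c2ccccc2)c(C)c1` gives > 50000 nM as a limit
- compound 2 `CCn1c(C(=O)NCCNC(=O)OC(C)(C)C)ccc1C(CC)(CC)c1ccc(OCS(=O)(=O)c2ccccc2)c(C)c1` gives > 50000 nM as a limit
- compound 3 `CCn1c(C(=O)NCCN)ccc1C(CC)(CC)c1ccc(OCS(=O)(=O)c2ccccc2)c(C)c1` gives 6470 nM as a true number

For the measured compounds named here, in a functional assay on MCF7 cells (Homo sapiens) for antiproliferative activity, read by MTT assay, with a stated time of 24 h (a lower number here means a stronger inhibitor, a higher number a weaker inhibitor), compound 3 gives 6470 nM as the only true number. Compound 1 and compound 2 reach only the limit of > 50000 nM in this assay, at which 2 of the 3 values shown sit, and no number. The change to compound 4 `CCn1c(C(=O)N[C@H](CO)C(C)C)ccc1C(CC)(CC)c1ccc(OCS(=O)(=O)c2ccccc2)c(C)c1` is 1-(hydroxymethyl)-2-methylpropyl in place of 2-aminoethyl on an amide-type nitrogen and puts 1-(hydroxymethyl)-2-methylpropyl in place of 2-aminoethyl on an amide-type nitrogen. Only compound 3 carries the 2-aminoethyl group, and two measured steps lead to it: an at least 7.7-fold lower number from compound 1 to compound 3 (0.88 log units; beyond the scatter) and an at least 7.7-fold lower number from compound 2 to compound 3 (0.88 log units; beyond the scatter) in the same direction. Compound 4 gives that group up, so a move back towards a higher number is expected. In this assay the estimated step is a 4.9-fold higher number from compound 3 to compound 4 (0.69 log units; beyond the scatter) towards a weaker inhibitor. Compound 4 is expected at 32000 nM with a range from 11000 nM to 70000 nM as its estimate.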

Compound 4, half-maximal inhibitory concentration: 25500 nM
Estimate against measurement, compound 4: 1.3-fold (0.10 log units) above; low and high end bracket the measured number.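

The 2-aminoethyl group is not required for a true number in this assay: 1-(hydroxymethyl)-2-methylpropyl on the same amide-type nitrogen still gives one, though with a 3.9-fold higher number from compound 3 to compound 4 (0.60 log units; beyond the scatter). Compared with the other two compounds, compound 4 shows an at least 1.9-fold lower number from compound 2 to compound 4 (0.29 log units; that floor lies within the scatter) and an at least 1.9-fold lower number from compound 1 to compound 4 (0.29 log units; that floor lies within the scatter). Those two steps are floors only, because each starts from a limit: the limit of > 50000 nM in this assay, at which 2 of the 4 values shown sit.

On these data alone, whether an amine on a longer chain would match or better compound 3 stays open. So does the question of how a carboxylic acid at this place would read.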